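Cap variation on a hydroxamic acid series: compound 4 outlook

A few compounds are considered here, and "the series" means these few. Any claim that something is new, unique, unknown or untested is made for them only; others in the source may bear on it.

Measured compounds:
- compound 1 `O=C(CCCCC[C@H](NC(=O)c1ccc(Br)cc1)C(=O)NCc1ccccc1)NO` — 5860 nM
- compound 2 `O=C(CCCCC[C@H](NC(=O)OCc1ccccc1)C(=O)NCc1ccccc1)NO` — 1520 nM
- compound 3 `O=C(CCCCC[C@H](NC(=O)c1ccc(C(F)(F)F)cc1)C(=O)NCc1ccccc1)NO` — 1610 nM

All three share one core and differ only in the group on the carbonyl carbon of the cap. In a functional assay on NFF cells (Homo sapiens) for antiproliferative activity (a higher number here means a weaker inhibitor, a lower number a stronger inhibitor), compound 1 gives 5860 nM. Compound 2 and compound 3 sit close together, and compound 3 stands second highest of the three numbers, its nearest neighbour being compound 2 and its furthest compound 1.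

Compound 4 `O=C(/C=C/c1c[nH]c2ccccc12)N[C@@H](CCCCCC(=O)NO)C(=O)NCc1ccccc1` is not yet measured. The change from compound 3: 2-(1H-indol-3-yl)ethenyl in place of 4-(trifluoromethyl)phenyl on a carbonyl carbon

For the measured compounds named here, the steps that bear on this cap change are a 3.9-fold lower number from compound 1 to compound 2 (0.59 log units; beyond the scatter) and a 3.6-fold lower number from compound 1 to compound 3 (0.56 log units; beyond the scatter), while a 1.1-fold higher number from compound 2 to compound 3 (0.02 log units; within the scatter) shows two caps landing together. Cap replacements in this set have therefore moved this assay by modest amounts at most. For compound 4 an estimate of 1000 nM is made, within a range of 300 nM to 3500 nM. This estimate corresponds to an expected step of a 1.6-fold lower number from compound 3 to compound 4 (0.21 log units; within the scatter), and the step is expected to be small, possibly within the scatter.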

Compound 4, half-maximal inhibitory concentration: 10400 nM
Compound 4: middle estimate off by 10-fold (1.02 log units), on the low side; the whole stated range lies below it.
By their numbers in this assay, from the lowest: compounds 2 and 3 (each within the scatter of the next); then compounds 1 and 4 (each within the scatter of the next).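

In this assay the group on the carbonyl carbon can do more than the earlier caps suggested: 2-(1H-indol-3-yl)ethenyl gives a 6.5-fold higher number from compound 3 to compound 4 (0.81 log units; beyond the scatter) and a 6.8-fold higher number from compound 2 to compound 4 (0.84 log units; beyond the scatter) and so separates clearly from the 4-(trifluoromethyl)phenyl and benzyloxy caps. With a 1.8-fold higher number from compound 1 to compound 4 (0.25 log units; within the scatter) it does not separate from the 4-bromophenyl cap, so the four compounds now form two pairs, compounds 2 and 3 against compounds 1 and 4, and sheer cap size does not track this split, since the entering group differs from 4-(trifluoromethyl)phenyl by little in heavy-atom count. No measurement at hand accounts for these steps.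

Still open, from the compounds shown here alone, is whether the change follows the ethenyl linker, the indole ring or its hydrogen-bond donor. An ethyl linker in place of the ethenyl, or a methyl group on the indole nitrogen, would begin to separate these parts.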